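The source may report more compounds than this note shows. Statements on the series, on what has been measured and on what is new or still open speak of the compounds shown alone.

In an ADME assay for solubility (a higher number here means a more soluble compound, a lower number a less soluble compound), compound 2, `CCCCCCCCCCCCCCSCC(COP(=O)(O)OP(=O)(O)OC[C@H]1OC(n2ccc(N)nc2=O)[C@@H](O)[C@@H]1O)OC(=O)CCCCCCCCCCC`, gives only a limit of the assay, > 50000000 nM. Compound 1, `CCCCCCCCCCCCCC(=O)OC(COP(=O)(O)OP(=O)(O)OC[C@H]1OC(n2ccc(N)nc2=O)[C@@H](O)[C@@H]1O)CSCCCCCCCCCCCC`, likewise gives only a limit in this assay, > 68000000 nM. Both readings are limits rather than numbers: one sits at the limit of > 50000000 nM in this assay, at which 1 of the 2 values shown sits, and the other at the limit of > 68000000 nM in this assay, at which 1 of the 2 values shown sits, so the two compounds cannot be ranked against each other on this assay.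

Compound 3, `CCCCCCCCCCCCCCSCC(COP(=O)(O)OP(=O)(O)OC[C@H]1OC(n2ccc(N)nc2=O)[C@@H](O)[C@@H]1O)OC(=O)CCCCCCCCCCCCC`, differs from compound 2 by ethyl in place of hydrogen on a saturated chain carbon, ten or more bonds along the chain from a carbonyl carbon. Among the measured compounds shown here, no step between two measured compounds is available here, so the size of the effect of such a change in this assay is not known from these data. Since compound 2 reached its limit of > 50000000 nM, compound 3 is expected to be reported again at or near a limit, with an estimated step of a number no higher from compound 2 to compound 3 (the limit leaves the size open) that stays within the usual scatter. Compound 3 is therefore estimated at 50000000 nM, between 15000000 nM and 70000000 nM.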

Compound 3, solubility: > 60000000 nM
Compound 3 ended at the assay's limit; the forecaster's own chance of this, stated with the estimate: 70%; middle value at least 1.2-fold (0.07 log units) from the limit.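

Among the compounds shown here, compound 3, like compound 1 and compound 2, is reported only as a limit in this assay, so no step to compound 3 from either of the others can be read. The compounds shown leave open the true reading of each one and whether ethyl in place of hydrogen changes it at all.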